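Adding fluoro to compound 3

The source may report more compounds than this note shows. Statements on the series, on what has been measured and on what is new or still open speak of the compounds shown alone.

compound 1 `O=C(NS(=O)(=O)c1ccccc1)c1cccnc1` gives 14400 nM
compound 2 `O=C(NS(=O)(=O)c1ccccc1)c1cccnc1Cl` gives 14000 nM
compound 3 `O=C(NS(=O)(=O)c1ccccc1)c1ccc(Cl)nc1` gives 14100 nM

All three values come from a functional assay on MCF7 cells (Homo sapiens) for antiproliferative activity, read by MTT assay, with a stated time of 48 h (a higher number here means a weaker inhibitor, a lower number a stronger inhibitor), and compound 3 stands level with compound 1 and compound 2, with every gap among them inside the scatter. The change from compound 3 to compound 4 `O=C(NS(=O)(=O)c1ccc(F)cc1)c1ccc(Cl)nc1` is fluoro in place of hydrogen on an aromatic carbon and amounts to fluoro in place of hydrogen on an aromatic carbon. For the measured compounds named here, two measured steps bear on it only loosely. Chloro in place of hydrogen on an aromatic carbon gave a 1.0-fold lower number from compound 1 to compound 2 (0.01 log units; within the scatter) and a 1.0-fold lower number from compound 1 to compound 3 (0.01 log units; within the scatter) and both lie within the scatter. Going by the values given here, neither step placed a group on the six-membered aromatic ring of carbon only, and no measured step shows fluoro there. No step beyond the scatter, in either direction, is therefore expected in this assay for this change, though the evidence is indirect. The expected size is a 1.2-fold lower number from compound 3 to compound 4 (0.07 log units; within the scatter) as estimated here. For compound 4 the expected value is 12000 nM in an estimated range from 5500 nM to 24000 nM when measured.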

Compound 4, half-maximal inhibitory concentration: 16800 nM
Beside the measured number, compound 4's estimate is 1.4-fold (0.15 log units) below it, and the stated range covers the measured number.
By their numbers in this assay, from the lowest: compounds 2, 3, 1 and 4 (each within the scatter of the next).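

Putting fluoro on the six-membered aromatic ring of carbon only, para to a large group, gave a 1.2-fold higher number from compound 3 to compound 4 (0.08 log units; within the scatter) in this assay. For the compounds shown here, this is the first measured change on that ring, and it shows that a single fluorine at this place, like the chloro steps elsewhere on the core, does not move the number beyond the scatter. Nothing measured here bears on the reason for this result.

The compounds shown leave open whether a larger group at the same place, such as an amine, a carboxylic acid or a longer chain, would produce a step beyond the scatter. They also do not tell whether fluoro at this place would behave the same way on compound 1.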